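A few compounds are considered here, and "the series" means these few. Any claim that something is new, unique, unknown or untested is made for them only; others in the source may bear on it.

Compound 1 `C=C(C)[C@@H]1CC=C(Cn2cc(COc3ccccc3C3NC(=O)NC(C)=C3C(=O)OCC)nn2)CC1` and compound 2 `C=C(C)[C@@H]1CC=C(Cn2cc(COc3cc(C4NC(=O)NC(C)=C4C(=O)OCC)ccc3OC)nn2)CC1` share one core and one assay. In a functional assay on MCF7 cells (Homo sapiens) for inhibition, read by sulforhodamine B assay, with a stated time of 48 h (on this read-out lower numbers stand for stronger inhibition of growth and higher numbers for weaker inhibition of growth), compound 1 gives > 100000 nM, which is a limit of the assay rather than a number. In this assay compound 2 gives > 100000 nM, likewise a limit and not a number. Both values shown fall at the same point: the limit of > 100000 nM in this assay, at which 2 of the 2 values shown sit. Going by the values given here, compound 2 therefore stands at the limit, and no step between measured compounds can be read. Compound 3 `C=C(C)[C@@H]1CC=C(Cn2cc(COc3cc(C4NC(=O)NC(C)=C4C(C)=O)ccc3OC)nn2)CC1` differs from compound 2 by methyl in place of ethoxy on a carbonyl carbon. Among the compounds with values here, no measured step bears on this change, so the step from compound 2 to compound 3 is expected to be a step that the limit leaves unreadable from compound 2 to compound 3, none beyond the scatter. Compound 3 is expected to give about 150000 nM in this assay, within 40000 nM to 600000 nM, most probably again reported only as a limit.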

Compound 3, concentration for total growth inhibition: > 100000 nM
Compound 3: only a limit was reported; the forecaster's own chance of this, stated with the estimate: 75%; the middle value lies beyond the limit too.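

Going by these compounds alone, compound 3 gives > 100000 nM in this assay, a limit and not a number, so no step from compound 2 can be read. Whether acetyl in place of ethoxycarbonyl alters growth inhibition, and any ranking of compound 1, compound 2 and compound 3, stay open: the limit of > 100000 nM in this assay, at which 3 of the 3 values shown sit.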